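Benzoylcarbamoyl Replaces the Side Chain of a Nucleoside Sulfonate

The source may report more compounds than this note shows. Statements on the series, on what has been measured and on what is new or still open speak of the compounds shown alone.

Among the measured compounds shown here, compound 3 `COC(=O)CNC1=CS(=O)(=O)O[C@@]12[C@@H](CO[Si](C)(C)C(C)(C)C)O[C@@H](n1cc(C)c(=O)n(C)c1=O)[C@@H]2O[Si](C)(C)C(C)(C)C` gives the only plain number in a functional assay on HEL cells (Homo sapiens) (on this read-out higher numbers stand for lower toxicity in this test and lower numbers for higher toxicity in this test), namely 160000 nM. Compound 1 `COC(=O)C(=O)CNC1=CS(=O)(=O)O[C@@]12[C@@H](CO[Si](C)(C)C(C)(C)C)O[C@@H](n1cc(C)c(=O)n(C)c1=O)[C@@H]2O[Si](C)(C)C(C)(C)C` returns > 200000 nM in this assay, which is a limit of the assay and not a number. Compound 2 `Cc1cn([C@@H]2O[C@@H]3COC(=O)[C@]3(OS(C)(=O)=O)[C@H]2O)c(=O)[nH]c1=O` likewise returns only a limit, >= 36000 nM. For the measured compounds named here, the single measured step, an at least 1.2-fold lower number from compound 1 to compound 3 (0.09 log units; that floor lies within the scatter), stays within the scatter. Compound 4 `Cc1cn([C@@H]2O[C@H](CO[Si](C)(C)C(C)(C)C)[C@@]3(OS(=O)(=O)C=C3NC(=O)NC(=O)c3ccccc3)[C@H]2O[Si](C)(C)C(C)(C)C)c(=O)n(C)c1=O` differs from compound 3 by benzoylcarbamoyl in place of (methoxycarbonyl)methyl on an amine nitrogen. Going by the values given here, no measured step exchanges the whole side chain on the amine nitrogen in this way, and the one step that touched this chain was small, so no shift beyond the scatter is expected in this assay. Compound 4 is therefore estimated at 150000 nM (range 40000 nM to 300000 nM), an expected step of a 1.1-fold lower number from compound 3 to compound 4 (0.03 log units; within the scatter).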

Compound 4, half-maximal cytotoxic concentration: >= 200000 nM
Compound 4: only a limit was reported (the forecaster's own chance of this, stated with the estimate: 50%); middle value at least 1.3-fold (0.12 log units) away from the limit.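

In this assay, benzoylcarbamoyl brings an aromatic ring and a hydrogen-bond donor to the amine nitrogen, neither of which (methoxycarbonyl)methyl has, and the result is an at least 1.2-fold higher number from compound 3 to compound 4 (0.09 log units; that floor lies within the scatter), so this wider exchange shows no shift that can be read beyond the scatter. Compound 4 gives >= 200000 nM, which is a limit of the assay and not a number. The step between compound 1 and compound 4 cannot be read.

As far as these compounds go, whether a carboxylic acid or a longer alkyl chain on this amine nitrogen would give a plain number in this assay remains open.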